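Extending the alkyl chain on a terpene-bearing triazole

This account rests on a few compounds, and the source may have more. Where it says the series, first, only, none or still open, it means among the compounds named here.

Measured compounds:
compound 1, `CCCCCCCCc1cn(C/C=C(/C)CCC=C(C)C)nn1`, with 6.92
compound 2, `CCCc1cn(C/C=C(/C)CCC=C(C)C)nn1`, with 4.05
compound 3, `CCCc1cn(C/C=C(\C)CC/C=C(\C)CCC=C(C)C)nn1`, with 6.5

These three compounds share a triazole core that carries a branched unsaturated chain on one side and a straight alkyl chain on the other. In a physicochemical assay for lipophilicity, measured as octanol-water partition (a lower number here means a more polar compound, a higher number a more lipophilic compound), compound 2 gives 4.05, the lowest of the three numbers. Compound 1 differs from compound 2 by pentyl in place of hydrogen on a saturated chain carbon, three bonds along the chain from an aromatic carbon, and this step makes the number a number 2.87 log units higher from compound 2 to compound 1 (beyond the scatter). Compound 3 gives 6.5 in this assay, the second highest number; its difference from compound 2 lies in the core and is not broken down here.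

Compound 4, `CCCCCCCCc1cn(C/C=C(\C)CC/C=C(\C)CCC=C(C)C)nn1`, has not yet been measured. It differs from compound 3 by pentyl in place of hydrogen on a saturated chain carbon, three bonds along the chain from an aromatic carbon, the same change that leads from compound 2 to compound 1, occurring here for the second time. Because the earlier step of a number 2.87 log units higher from compound 2 to compound 1 (beyond the scatter) was large and well beyond the scatter, a step of similar size is expected from compound 3 to compound 4, namely a number 2.80 log units higher from compound 3 to compound 4 (beyond the scatter). This expectation rests on a single earlier step, so the range is kept wide. Compound 4 is therefore estimated at 9.3, between 8.5 and 10.1 in this assay.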

Compound 4, partition coefficient: 8.76
For compound 4 the middle estimate is 0.54 log units above the measured one, within the range that was stated.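

In this assay, the change from hydrogen to pentyl on a saturated chain carbon, three bonds along the chain from an aromatic carbon, has now been seen on two different cores, and both steps are large (a number 2.87 log units higher from compound 2 to compound 1 (beyond the scatter); a number 2.26 log units higher from compound 3 to compound 4 (beyond the scatter)). Within these four compounds the change therefore carries over from one core to the other in direction and roughly in size, although the step on the core of compound 3 is the smaller of the two as printed, and two cases cannot show whether the same would hold on any further core. The data offer no explanation for the difference in size between the two steps.

The compounds shown leave open whether the number would keep rising by similar amounts along a longer chain than octyl, since only propyl and octyl appear here at this place on each core. They also leave open what this assay would read if an amine or a carboxylic acid stood at the end of the chain, as every chain shown here is a plain unbranched run of carbons.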